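A few compounds are considered here, and "the series" means these few. Any claim that something is new, unique, unknown or untested is made for them only; others in the source may bear on it.

Working notes on the series. The compounds share one core and differ only in the aryl group on a carbon with a double bond to nitrogen. Compound 1 `COc1cc(/C=N/NC(=O)Nc2ccc(Oc3ccnc(-c4nncn4CCN(C)C)c3)c(F)c2)cc(OC)c1OC` gives 2900 nM in a functional assay on MKN-45 cells (Homo sapiens) for cytotoxicity, read by MTT assay, with a stated time of 72 h; a higher number here means a weaker inhibitor, a lower number a stronger inhibitor. Compound 2 `CN(C)CCn1cnnc1-c1cc(Oc2ccc(NC(=O)N/N=C/c3cc(Br)c(O)c(Br)c3)cc2F)ccn1` gives 4320 nM in this assay, and compound 3 `COc1ccc(/C=N/NC(=O)Nc2ccc(Oc3ccnc(-c4nncn4CCN(C)C)c3)c(F)c2)cc1O` gives 2510 nM. Compound 3 carries the lowest of the three numbers, but its nearest neighbour is reached by a 1.2-fold lower number from compound 1 to compound 3 (0.06 log units; within the scatter) and its furthest by a 1.7-fold lower number from compound 2 to compound 3 (0.24 log units; within the scatter), and the remaining pair shows a 1.5-fold higher number from compound 1 to compound 2 (0.17 log units; within the scatter); the three measured compounds thus sit within the scatter of one another. Compound 4 `COc1cc(/C=N/NC(=O)Nc2ccc(Oc3ccnc(-c4nncn4CCN(C)C)c3)c(F)c2)ccc1O` is not yet measured and differs from compound 3 in one place: 4-hydroxy-3-methoxyphenyl in place of 3-hydroxy-4-methoxyphenyl on a carbon with a double bond to nitrogen. Going by the values given here, no measured step swaps hydroxy and methoxy positions, yet all three measured steps, each exchanging the whole aryl group, stayed within the scatter, and here compound 3 and compound 4 have the same atoms, joined differently. For compound 4 the expected step is a 1.1-fold higher number from compound 3 to compound 4 (0.03 log units; within the scatter), no change beyond the scatter. Compound 4 is therefore estimated at 2700 nM in this assay, with a range of 1300 nM to 5600 nM.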

Compound 4, half-maximal inhibitory concentration: 3780 nM
Compound 4: middle estimate off by 1.4-fold (0.15 log units), on the low side; measured number inside the range.
By their numbers in this assay, from the lowest: compounds 3, 1, 4 and 2 (each within the scatter of the next).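

The hydroxy and methoxy swap, with the same atoms joined differently, gives a 1.5-fold higher number from compound 3 to compound 4 (0.18 log units; within the scatter) in this assay and so stays as small as the exchanges of the whole aryl group. The other two new steps, a 1.1-fold lower number from compound 2 to compound 4 (0.06 log units; within the scatter) and a 1.3-fold higher number from compound 1 to compound 4 (0.12 log units; within the scatter), also stay within the scatter, so neither the placing of these two groups nor the exchanges of the whole aryl group separate the four compounds at this position. No measurement bearing on this result is available.

Going by these compounds, all four aryl groups carry only hydroxy, methoxy or bromo substituents, so the effect of an amine or a carboxylic acid on the ring remains open. Also open, on these data alone, is whether a longer alkyl chain in place of the aryl group on this carbon would stay within the scatter.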